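A smaller amide substituent on a weak phosphatase inhibitor

This account rests on a few compounds, and the source may have more. Where it says the series, first, only, none or still open, it means among the compounds named here.

Three compounds have been measured in an assay on isolated protein for inhibition of receptor-type tyrosine-protein phosphatase C (Homo sapiens), read by spectrophotometry; a higher number here means a weaker inhibitor, a lower number a stronger inhibitor:

Compound 1 `Oc1cc(-c2ccccc2)ccc1C(O)(C(F)(F)F)C(F)(F)F` gives > 500000 nM, which is a limit of the assay and not a number.
Compound 2 `O=C(COc1ccc2cc(C(O)(C(F)(F)F)C(F)(F)F)c(O)cc2c1)NCc1ccccc1` gives > 20000 nM, again a limit and not a number.
Compound 3 `O=C(COc1ccc2cc(C(O)(C(F)(F)F)C(F)(F)F)c(O)cc2c1)N(c1ccccc1)c1ccccc1` gives 14900 nM.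

All three carry the same fluorinated carbinol on a phenol. Going by the values given here, compound 2 stands at a limit (the limit of > 20000 nM in this assay, at which 1 of the 3 values shown sits), so its potency is known only to be weak; compound 1 sits at a different limit (the limit of > 500000 nM in this assay, at which 1 of the 3 values shown sits), and compound 3 is the only one with a measured number. Among the compounds with values here, no single-change step between two measured compounds is available, so the size of any step can only be expected, not read off.

Compound 4 `O=C(COc1ccc2cc(C(O)(C(F)(F)F)C(F)(F)F)c(O)cc2c1)NC1CC1` differs from compound 2 in one place: cyclopropyl in place of benzyl on an amide-type nitrogen. Since compound 2 is itself only a limit, the step from compound 2 to compound 4 cannot be judged against the scatter; the expectation is no step beyond it, with the limit likely to reappear, which is what a step that the limit leaves unreadable from compound 2 to compound 4 expresses. Compound 4 is therefore expected to show about 40000 nM, within a range from 15000 nM to 150000 nM.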

Compound 4, half-maximal inhibitory concentration: > 20000 nM
Compound 4: a limit, no number; the forecaster's own chance of this, stated with the estimate: 70%; the middle value is on the limit's open side.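

Compound 2 and compound 4 each stand at a limit of the assay and not at a number, and no step can be read between them: the limit of > 20000 nM in this assay, at which 2 of the 4 values shown sit. The compounds shown leave open how strong either compound truly is, and whether cyclopropyl in place of benzyl on the amide-type nitrogen changes potency at all.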